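Ethyl removal on the shared core, following compound 2

This account rests on a few compounds, and the source may have more. Where it says the series, first, only, none or still open, it means among the compounds named here.

Measured compounds:
compound 1 `CCCc1nc(C)c2c(CC)nnc(SC)n12`: > 48000 nM
compound 2 `CCCc1nc(C)c2c(CC)nnc(S)n12`: > 48000 nM
compound 3 `CCCc1nc(C)c2c(CC)nnc(O)n12`: 15600 nM

In a functional assay for inhibition, with Homo sapiens as the target (on this read-out higher numbers stand for weaker inhibition and lower numbers for stronger inhibition), compound 2 gives > 48000 nM, which is a limit of the assay rather than a number. Compound 1 likewise sits at a limit, (the limit of > 48000 nM in this assay, at which 2 of the 3 values shown sit). Only compound 3 gives a number, and the steps of an at least 3.0-fold lower number from compound 1 to compound 3 (0.48 log units; beyond the scatter) and an at least 3.0-fold lower number from compound 2 to compound 3 (0.48 log units; beyond the scatter) concern the sulfur-bearing group, not the ethyl.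

Compound 4 `CCCc1nc(C)c2cnnc(S)n12` keeps the sulfanyl group of compound 2 and differs by hydrogen in place of ethyl on an aromatic carbon. Going by the values given here, no measured step touches this position, so no direction can be read from the series. Compound 4 is expected near the limit again, estimated at 60000 nM (range 15000 nM to 240000 nM), meaning an expected step that the limit leaves unreadable from compound 2 to compound 4.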

Compound 4, half-maximal inhibitory concentration: 10000 nM
Compound 4: the middle estimate sits 6.0-fold (0.78 log units) above what was measured; measured number outside the range, below it.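

In this assay, going by these compounds alone, hydrogen in place of ethyl on this aromatic carbon gives an at least 4.8-fold lower number from compound 2 to compound 4 (0.68 log units; beyond the scatter), the first readable change at a position that no earlier step touched. With the sulfanyl group in place, the ethyl is not required for a measurable number. Compound 2 stands at a limit, so the size of this step is a floor only: the limit of > 48000 nM in this assay, at which 2 of the 4 values shown sit.

On these data alone, whether an amine or a longer chain on this carbon would lower the number further remains open. Also open, as far as these compounds go, is whether removing the ethyl has a similar result with the hydroxy or methylsulfanyl group in place of the sulfanyl group.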